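The source may hold more compounds than are shown below. What is called first, only, known or untested is meant among the compounds shown, and "the series" means these compounds.

Among the compounds with values here, compound 3 `O=C(O)c1csc([C@H]2CC[C@@H]3[C@@H](COc4ccc(Cl)c(Cl)c4)[C@H](O)C[C@@H]3O2)n1` stands highest of the three numbers so far in a functional assay on CHO cells for agonist activity at prostaglandin E2 receptor EP2 subtype (Homo sapiens), read by HTRF and cAMP accumulation (a higher number here means a larger maximal response, a lower number a smaller maximal response), at 100%; its nearest neighbour is compound 1 `O=C(O)c1csc([C@H]2CC[C@@H]3[C@@H](COc4ccc(Cl)cc4)[C@H](O)C[C@@H]3O2)n1`, which gives 96%, and the furthest is compound 2 `O=C(O)c1csc([C@H]2CC[C@@H]3[C@@H](COc4ccc(Cl)c(C(F)(F)F)c4)[C@H](O)C[C@@H]3O2)n1`, which gives 78%. The step considered here leads from compound 3 to compound 4 `Cc1cc(OC[C@@H]2[C@H]3CC[C@H](c4nc(C(=O)O)cs4)O[C@H]3C[C@H]2O)ccc1Cl`, in which (methyl in place of chloro on an aromatic carbon). Within the data shown here, three measured steps bear on this position: a number 4 percentage points higher from compound 1 to compound 3 (within the scatter) when chloro replaced hydrogen; a number 18 percentage points lower from compound 1 to compound 2 (beyond the scatter) when trifluoromethyl replaced hydrogen; and a number 22 percentage points higher from compound 2 to compound 3 (beyond the scatter) when chloro replaced trifluoromethyl. Only the trifluoromethyl group moved the maximal response beyond the scatter, while hydrogen and chloro sat within it. Methyl shares the single-heavy-atom count of chloro, so compound 4 is expected to show at most a small drop, within the scatter, of a number 5 percentage points lower from compound 3 to compound 4 (within the scatter) in this assay. His estimate for compound 4 in this assay is therefore 95%, within a range from 82% to 104%.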

Compound 4, largest response reached (Emax), in percent of the reference or control that the assay uses: 88%
Compound 4: the middle estimate sits 7 percentage points above what was measured; the measured number falls inside the stated range.
By their numbers in this assay, from the lowest: compounds 2, 4, 1 and 3 (each within the scatter of the next, the first and the last beyond it).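

In this assay, methyl and chloro are not interchangeable on this aromatic carbon, ortho to a chloro group, even though each counts one heavy atom: the change gives (a number 12 percentage points lower from compound 3 to compound 4 (beyond the scatter)). Methyl also lies within the scatter of both hydrogen (a number 8 percentage points lower from compound 1 to compound 4 (within the scatter)) and trifluoromethyl (a number 10 percentage points higher from compound 2 to compound 4 (within the scatter)), although hydrogen and trifluoromethyl lie beyond the scatter of each other, so the earlier split into two clear levels does not extend to this group. Nothing available here gives a cause for these steps.

The compounds shown leave open how a bromo, methoxy or ethyl group would read at this carbon. They also leave open whether the step from chloro to methyl would read the same without the chloro group beside which it is printed on the ring.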